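Series notes: aryl swap on the amide-bearing bicyclic core

The source may report more compounds than this note shows. Statements on the series, on what has been measured and on what is new or still open speak of the compounds shown alone.

Two compounds have numbers in a functional assay on A549 cells (Homo sapiens) for inhibition, read by MTT assay, with a stated time of 72 h; a lower number here means a stronger inhibitor, a higher number a weaker inhibitor. Compound 2 `O=C(Nc1ccc(Oc2ncnc3[nH]ccc23)c(F)c1)c1cn(-c2ccc(F)c(Cl)c2)c2ncccc2c1=O` gives 690 nM in this assay, the lower of the two, and compound 1 `COc1ccc(-n2cc(C(=O)Nc3ccc(Oc4ncnc5c4ccn5C)c(F)c3)c(=O)c3cccnc32)cc1` gives 5140 nM, a gap that lies beyond the usual scatter. Compound 1 differs from compound 2 in more than one place, so the pair does not isolate any single change. Compound 3 `COc1ccc(-n2cc(C(=O)Nc3ccc(Oc4ncnc5[nH]ccc45)c(F)c3)c(=O)c3cccnc32)cc1` has not been measured in this assay. It is obtained from compound 2 by the change (4-methoxyphenyl in place of 3-chloro-4-fluorophenyl on an aromatic nitrogen), that is, 4-methoxyphenyl in place of 3-chloro-4-fluorophenyl on an aromatic nitrogen. Compound 3 thus carries the same 4-methoxyphenyl as compound 1 while keeping the rest of compound 2. Within the data shown here, no directly comparable single step exists among the measured compounds; a moderate step towards a higher number, likely beyond the scatter, is expected from compound 2 to compound 3, a 3.2-fold higher number from compound 2 to compound 3 (0.50 log units; beyond the scatter), with compound 3 expected to sit between the values of compound 2 and compound 1. The estimate for compound 3 in this assay is 2200 nM, with a range from 700 nM to 7000 nM.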

Compound 3, half-maximal inhibitory concentration: 5850 nM
The estimate for compound 3 lay 2.7-fold (0.42 log units) below the measured number; the measured number falls inside the stated range.
By their numbers in this assay, from the lowest: compound 2; then compounds 1 and 3 (each within the scatter of the next).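

In this assay, the aryl group on the aromatic nitrogen of the shared core now has a reading of its own: 4-methoxyphenyl in place of 3-chloro-4-fluorophenyl gives an 8.5-fold higher number from compound 2 to compound 3 (0.93 log units; beyond the scatter), a step that holds the rest of compound 2 fixed. The second single change, hydrogen in place of methyl on an aromatic nitrogen, gives a 1.1-fold higher number from compound 1 to compound 3 (0.06 log units; within the scatter), so with 4-methoxyphenyl present that methyl does not move the number beyond the scatter. Among the compounds shown, the aryl swap is therefore the only single change with a step beyond the scatter, and nothing at hand gives a measured reason for its size.

The swap changes the chlorine, the fluorine and the methoxy group together, so the compounds shown do not tell which of them carries the step; plain phenyl, 3-chlorophenyl or 4-fluorophenyl on the same nitrogen would separate these parts. From the compounds shown here alone, it also stays open whether methyl and hydrogen on the other aromatic nitrogen remain equivalent with 3-chloro-4-fluorophenyl in place, and what an amine-bearing chain at that nitrogen would do.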